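Oxadiazole aryl substituent series on a shared core

A few compounds are considered here, and "the series" means these few. Any claim that something is new, unique, unknown or untested is made for them only; others in the source may bear on it.

Measured in a functional assay on HCT-116 cells (Homo sapiens) for inhibition, read by MTT assay, with a stated time of 24 h, tested at 5 uM; on this read-out lower numbers stand for less inhibition of growth and higher numbers for more inhibition of growth at the one concentration tested:
compound 1 `CS(=O)(=O)c1ccc(-c2cnc3[nH]cc(-c4nnc(-c5ccc(Cl)cc5)o4)c(=O)c3c2)cc1` gives 16.4%
compound 2 `CS(=O)(=O)c1ccc(-c2cnc3[nH]cc(-c4nnc(-c5cccnc5)o4)c(=O)c3c2)cc1` gives 9.26%
compound 3 `Cc1ccc(-c2nnc(-c3c[nH]c4ncc(-c5ccc(S(C)(=O)=O)cc5)cc4c3=O)o2)cc1` gives 20.4%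

Compound 3 stands highest of the three numbers, but its gap to compound 1 is within the scatter: a number 4 percentage points higher from compound 1 to compound 3 (within the scatter). Going by the values given here, only the step from compound 2 goes beyond it: a number 11.1 percentage points higher from compound 2 to compound 3 (beyond the scatter), a modest size.

Compound 4 `CS(=O)(=O)c1ccc(-c2cnc3[nH]cc(-c4nnc(-c5ccccc5)o4)c(=O)c3c2)cc1` differs from compound 3 by hydrogen in place of methyl on an aromatic carbon. Among the compounds with values here, the one step that bears on this ring position, chloro to methyl, was a number 4 percentage points higher from compound 1 to compound 3 (within the scatter), so a small group at this place has not moved the number beyond the scatter. No step beyond the scatter is therefore expected for compound 4, a number 3.4 percentage points lower from compound 3 to compound 4 (within the scatter); compound 4 is estimated at 17%, within 8% to 26%.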

Compound 4, percent growth inhibition at one concentration: 8.6%
Compound 4: the middle estimate sits 8.4 percentage points above what was measured, within the range that was stated.
By their numbers in this assay, from the lowest: compounds 4, 2, 1 and 3 (each within the scatter of the next, the first and the last beyond it).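

Hydrogen and methyl on this phenyl ring do separate (a number 11.8 percentage points lower from compound 3 to compound 4 (beyond the scatter)), whereas hydrogen and chloro do not (a number 7.8 percentage points lower from compound 1 to compound 4 (within the scatter)), so at this place the number depends on which group is present, and a small group does not always leave it within the scatter. Phenyl and pyridin-3-yl are not told apart (a number 0.7 percentage points lower from compound 2 to compound 4 (within the scatter)), so among these compounds only 4-methylphenyl stands beyond the scatter of phenyl and pyridin-3-yl, while 4-chlorophenyl stands within the scatter of all three. No data at hand explain the methyl step.

Open, from the compounds shown here alone, is whether ethyl, methoxy or a longer chain at this place would follow methyl. Also open, going by these compounds, is how an amine or a carboxylic acid there would read in this assay.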